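This account rests on a few compounds, and the source may have more. Where it says the series, first, only, none or still open, it means among the compounds named here.

Working notes on the series built on the shared core of compound 1 `O=C(Nc1cccc(Cl)c1)c1cc(Br)cc(Br)c1O`, which in an assay for inhibition of HSP60/HSP10 (Homo sapiens), with a stated time of 60 min (on this read-out lower numbers stand for stronger inhibition and higher numbers for weaker inhibition), gives 29000 nM. Compound 2 `COc1c(Br)cc(Br)cc1C(=O)Nc1ccccc1` in this assay gives only the limit > 100000 nM, not a number. Compound 3 `O=C(Nc1ccccc1)c1cc(Br)cc(Br)c1` in this assay likewise gives only the limit > 100000 nM, not a number. The step that the two limits leave unreadable from compound 2 to compound 3 is thus unreadable, since both sit at the limit of > 100000 nM in this assay, at which 2 of the 3 values shown sit. Compound 4 `O=C(Nc1cccc(Cl)c1)c1cc(Br)cc(Br)c1` differs from compound 3 by chloro in place of hydrogen on an aromatic carbon. Within the data shown here, no measured step bears on this change, and compound 3 at the limit sets no direction, so no step beyond the scatter is expected. The step that the limit leaves unreadable from compound 3 to compound 4 is an estimate only. Compound 4 is expected in this assay near 120000 nM, within 40000 nM to 400000 nM, most likely again reported as a limit.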

Compound 4, half-maximal inhibitory concentration: > 100000 nM
Compound 4: a limit, no number; the forecaster's own chance of this, stated with the estimate: 70%; the middle value does not contradict the limit.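

In this assay, among these compounds, the hydroxy position gives the first readable step, with hydrogen in place of hydroxy on the aromatic carbon: there is an at least 3.4-fold higher number from compound 1 to compound 4 (0.53 log units; beyond the scatter). Of the compounds shown, only compound 1 carries the hydroxy, and only compound 1 gives a number. Compound 4 gives a limit, not a number, and the steps among the compounds at the limit cannot be read: the limit of > 100000 nM in this assay, at which 3 of the 4 values shown sit.

Going by these compounds, what the chloro group contributes with the hydroxy present remains open. So does whether an amine or a carboxylic acid at the hydroxy position would give a number.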